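Notes on the amine-nitrogen substituent in this series

A few compounds are considered here, and "the series" means these few. Any claim that something is new, unique, unknown or untested is made for them only; others in the source may bear on it.

Compound 1 `CC(C)N1CCN(c2nc(Nc3ccc(C#N)c(C(F)(F)F)c3)nc(Oc3ccnc4ccccc34)n2)CC1` carries isopropyl on an amine nitrogen in a ring. In a functional assay on DU-145 cells (Homo sapiens) for cytotoxicity, read by sulforhodamine B assay, with a stated time of 48 h (on this read-out higher numbers stand for weaker inhibition of growth and lower numbers for stronger inhibition of growth), compound 1 gives > 100000 nM, which is a limit of the assay and not a number. Compound 2 `N#Cc1ccc(Nc2nc(Oc3ccnc4ccccc34)nc(N3CCN(c4ccccc4F)CC3)n2)cc1C(F)(F)F` carries 2-fluorophenyl in the same place. In this assay compound 2 gives > 100000 nM, again a limit rather than a number. Among the compounds with values here, compound 3 `N#Cc1ccc(Nc2nc(Oc3ccnc4ccccc34)nc(N3CCN(c4ccccn4)CC3)n2)cc1C(F)(F)F` carries pyridin-2-yl there, and in this assay compound 3 gives 85900 nM, the only number among the three values shown; the other two sit at the limit of > 100000 nM in this assay, at which 2 of the 3 values shown sit. The step of an at least 1.1-fold lower number from compound 1 to compound 3 (0.06 log units; that floor lies within the scatter) and the step of an at least 1.1-fold lower number from compound 2 to compound 3 (0.06 log units; that floor lies within the scatter) are therefore read only as floors, both within the scatter, while the step that the two limits leave unreadable from compound 1 to compound 2 cannot be read at all.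

Compound 4 `COc1ccc(N2CCN(c3nc(Nc4ccc(C#N)c(C(F)(F)F)c4)nc(Oc4ccnc5ccccc45)n3)CC2)cc1` is not yet measured. The change is 4-methoxyphenyl in place of pyridin-2-yl on an amine nitrogen in a ring. It exchanges one six-membered aromatic group on the ring nitrogen for another, as did the move from compound 2 to compound 3, whose floor lay within the scatter. Within the data shown here, no measured step in this place is beyond the scatter, so in this assay no shift beyond the scatter is expected, with the value possibly returning to the limit. The expected step is a 1.2-fold higher number from compound 3 to compound 4 (0.07 log units; within the scatter). For compound 4 the estimate in this assay is 100000 nM within 40000 nM to 250000 nM.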

Compound 4, concentration for 50% growth inhibition: > 100000 nM
Compound 4: only a limit was reported; the forecaster's own chance of this, stated with the estimate: 60%; the middle value lies on the limit itself.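

In this assay compound 4 gives a limit of the assay and not a number, so isopropyl, 2-fluorophenyl and 4-methoxyphenyl on the amine nitrogen in the ring now all stand at one limit: the limit of > 100000 nM in this assay, at which 3 of the 4 values shown sit.

Within the data shown here, exchanging pyridin-2-yl for 4-methoxyphenyl, a carbon-only aromatic ring of 8 heavy atoms in place of one of 6 with a ring nitrogen, gives an at least 1.1-fold higher number from compound 3 to compound 4 (0.06 log units; that floor lies within the scatter), which is a floor within the scatter, so this position still shows no step of readable size. The steps to compound 4 from compound 1 and from compound 2 cannot be read, as both ends of each are limits.

Among these compounds, whether the ring nitrogen of pyridin-2-yl matters at all stays open, since the single number of compound 3 is not separated from the limit by more than the scatter, and plain phenyl at this place would be the direct comparison for both pyridin-2-yl and 4-methoxyphenyl. Also open, on these data alone, is whether any group here, such as a carboxylic acid or a longer chain ending in an amine, gives a value clearly below the limit in this assay.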